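The source may report more compounds than this note shows. Statements on the series, on what has been measured and on what is new or still open speak of the compounds shown alone.

Of the compounds shown here, two have been measured in a physicochemical assay for lipophilicity, read by HPLC, measured as octanol-water partition; a lower number here means a more polar compound, a higher number a more lipophilic compound. Compound 1, with the structure `COc1ccc(N(CC(=O)NCCC[Te]c2ccccc2)C(=O)CNC(=O)OC(C)(C)C)cc1`, gives 4.2 in this assay. Compound 2, with the structure `COc1ccc(N(CC(=O)NCCCSc2ccccc2)C(=O)c2ccccc2)cc1`, gives 3.1 in this assay, the lowest of the two numbers; its nearest neighbour is compound 1, whose number is higher by more than the usual scatter. For the measured compounds named here, the two structures differ in more than one place, so no single step between them can be read.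

Compound 3, with the structure `COc1ccc(N(CC(=O)NCCC[Te]c2ccccc2)C(=O)c2ccccc2)cc1`, has not yet been measured. It differs from compound 2 in one place: a group of 7 heavy atoms (6 carbon, 1 tellurium; one six-membered aromatic ring of carbon only) in place of a group of 7 heavy atoms (6 carbon, 1 sulfur; one six-membered aromatic ring of carbon only), on a saturated chain carbon, three bonds along the chain from an amide-type nitrogen. Going by the values given here, no measured pair shows this exact change on its own. Still, compound 1 carries the same tellurium-bearing group and stands at 4.2, so an upward step in this assay is expected, of moderate size. The expected step from compound 2 to compound 3 is a number 0.50 log units higher from compound 2 to compound 3 (beyond the scatter). For compound 3 the estimate in this assay is 3.6, with a likely range from 3.2 to 4.1.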

Compound 3, partition coefficient: 1.72
Estimate against measurement, compound 3: 1.88 log units above; measured number below the stated range.
By their numbers in this assay, from the lowest: compound 3; then compound 2; then compound 1.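

In this assay, for the compounds shown here, the exchange of the sulfur-bearing phenylsulfanyl group for its tellurium counterpart, on a saturated chain carbon, three bonds along the chain from an amide-type nitrogen, gives a number 1.38 log units lower from compound 2 to compound 3 (beyond the scatter) and is the first direct reading of this change, showing that at this position, on this core, tellurium in place of sulfur goes with a lower number. The high number of compound 1 therefore cannot be credited to the tellurium-bearing group alone, since phenyl in place of ((tert-butoxycarbonyl)amino)methyl on a carbonyl carbon gives a number 2.48 log units lower from compound 1 to compound 3 (beyond the scatter) with that group unchanged. Nothing available here accounts for either step.

Whether tellurium in place of sulfur would also lower the number on the core of compound 1 stays open, as the only such pair shown is the one with the phenyl on the carbonyl carbon. Also open, on these data alone, is how a selenium atom at the same position, or a longer chain carrying the tellurium-bearing group, would read in this assay on this core.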